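This account rests on a few compounds, and the source may have more. Where it says the series, first, only, none or still open, it means among the compounds named here.

Measured compounds:
compound 1 `COc1cc(N2C(N)=C(C#N)C(c3cccs3)C3=C2CC(C)(C)CC3=O)cc(OC)c1OC` with 15% in a functional assay on Ehrlich cells (Mus musculus) for cytotoxicity, tested at 50 ug/mL; a higher number here means a stronger effect of the compound at the concentration tested, a lower number a weaker effect;
compound 2 `COc1cc(N2C(N)=C(C#N)C(c3ccccc3O)C3=C2CC(C)(C)CC3=O)cc(OC)c1OC` with 2% in this assay;
compound 3 `COc1cc(N2C(N)=C(C#N)C(c3ccccc3)C3=C2CC(C)(C)CC3=O)cc(OC)c1OC` with 8% in this assay.

Compound 3 sits between the other two, but both gaps are small: the step of a number 7 percentage points lower from compound 1 to compound 3 (within the scatter) and the step of a number 6 percentage points higher from compound 2 to compound 3 (within the scatter) are each within the scatter, so no order among compounds 1, 3 and 2 can be read from these three numbers. Going by the values given here, the only step beyond the scatter among the measured compounds is a number 13 percentage points lower from compound 1 to compound 2 (beyond the scatter).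

Compound 4 `COc1cc(N2C(N)=C(C#N)C(c3ccc(C)o3)C3=C2CC(C)(C)CC3=O)cc(OC)c1OC` differs from compound 3 in one place: 5-methylfuran-2-yl in place of phenyl on a saturated ring carbon The step that bears most directly on this change is a number 7 percentage points lower from compound 1 to compound 3 (within the scatter), where a five-membered aromatic ring with one hetero atom stood on the same saturated ring carbon and the outcome was within the scatter of the phenyl compound. Among the compounds with values here, nothing among the measured compounds tests a methyl on that ring, so the expectation rests on that one step. Compound 4 is therefore expected to give 11% in this assay, with a range from 2% to 22%, which amounts to an expected step of a number 3 percentage points higher from compound 3 to compound 4 (within the scatter) that would lie within the scatter.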

Compound 4, a percentage reported as activity, at one concentration (the size of the read-out at that concentration, not a potency): 41%
For compound 4 the middle estimate is 30 percentage points below the measured one; the whole stated range lies below it.
By their numbers in this assay, from the lowest: compounds 2, 3 and 1 (each within the scatter of the next, the first and the last beyond it); then compound 4.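

In this assay, going by these compounds alone, the group on this saturated ring carbon can shift the read-out much further than the earlier compounds showed, with 5-methylfuran-2-yl in place of phenyl giving a number 33 percentage points higher from compound 3 to compound 4 (beyond the scatter) and the same group in place of 2-hydroxyphenyl giving a number 39 percentage points higher from compound 2 to compound 4 (beyond the scatter). The third step, a number 26 percentage points higher from compound 1 to compound 4 (beyond the scatter), replaces thiophen-2-yl, which is also a five-membered aromatic ring with one hetero atom, so having such a ring at this carbon does not by itself give the higher number. Nothing available explains why this change has so large an effect.

The change brings in the furan oxygen and the methyl together, so the compounds shown do not tell which of them carries the gain; furan-2-yl without the methyl and 5-methylthiophen-2-yl would separate the two. Also open, on these data alone, is what happens when the methyl on the furan gives way to a longer chain such as propyl or to an aminomethyl group, and whether the gain holds at concentrations other than the single one used here.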